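A Methyl on the Pyridine: What Compound 4 May Give

This account rests on a few compounds, and the source may have more. Where it says the series, first, only, none or still open, it means among the compounds named here.

Compound 1, `Cc1ccc(Oc2ccc3nc(COc4cccc(C(=O)O)c4)n(C)c3n2)c(C)c1`: 28.8 10^-6 cm/s
Compound 2, `Cn1c(COc2cccc(C(=O)O)c2)nc2ccc(Oc3ccc4c(c3)OCC4)nc21`: 9.1 10^-6 cm/s
Compound 3, `Cn1c(COc2cccc(C(=O)O)c2)nc2ccc(Oc3ccccn3)cc21`: 2.2 10^-6 cm/s

All three compounds share one core and differ only in the aromatic group attached to the ether oxygen. In an ADME assay for permeability, using PAMPA, with a stated time of 4 h (a higher number here means that the compound crosses the layer faster, a lower number that the compound crosses the layer more slowly), compound 1 gives the highest number, compound 2 a lower one, and compound 3, which carries a pyridin-2-yl on that oxygen, the lowest of the three, clearly apart from both others. Going by the values given here, the only step between two compounds that differ in a single place is a 3.2-fold lower number from compound 1 to compound 2 (0.50 log units; beyond the scatter).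

Compound 4, `Cc1ccnc(Oc2ccc3nc(COc4cccc(C(=O)O)c4)n(C)c3c2)c1`, differs from compound 3 by methyl in place of hydrogen on an aromatic carbon. No measured step is of this kind: the one step shown exchanges the whole group on the ether oxygen, while here a methyl is added to an otherwise unchanged ring. The numbers therefore give no basis for a step in either direction, and the expectation is a change that stays within the usual scatter, with somewhat more room on the upper side.

Compound 4 is thus expected to give about 3.2 10^-6 cm/s, within a range of 1.4 10^-6 cm/s to 7.5 10^-6 cm/s, which corresponds to an estimated step of a 1.5-fold higher number from compound 3 to compound 4 (0.16 log units; within the scatter).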

Compound 4, apparent permeability: 3.5 10^-6 cm/s
For compound 4 the middle estimate is 1.1-fold (0.04 log units) below the measured one; the measured number falls inside the stated range.
By their numbers in this assay, from the lowest: compounds 3 and 4 (each within the scatter of the next); then compound 2; then compound 1.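

In this assay, going by these compounds alone, the first single-place change on the pyridin-2-yl group, methyl in place of hydrogen on an aromatic carbon opposite the ring nitrogen, gives a 1.6-fold higher number from compound 3 to compound 4 (0.20 log units; within the scatter) and so stays inside the normal spread of repeat measurements. The pyridin-2-yl and 4-methylpyridin-2-yl compounds therefore cannot be told apart in this read-out, and this one extra carbon at this position leaves the number where repeat measurements could also have put it. Nothing measured here offers an explanation for this result, and a step this small gives little that would need one.

The compounds shown leave open whether a different group at this same place, such as an ethyl chain, a methoxy group, an amine or a carboxylic acid, would shift the number beyond the scatter. They also leave open whether a methyl on another carbon of this ring would behave as this one does, so the result describes this single position and this single change, not methyl groups on the ring in general.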